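A few compounds are considered here, and "the series" means these few. Any claim that something is new, unique, unknown or untested is made for them only; others in the source may bear on it.

Compound 1, `N=C(N)c1ccc(O)c(CCCNC(=O)c2ccc(-c3ncc[nH]3)cc2)c1`. In an assay on isolated protein for inhibition of serine protease 1 (Homo sapiens) (a lower number here means a stronger inhibitor, a higher number a weaker inhibitor), compound 1 gives about 2900 nM.
Compound 2, `N=C(N)c1ccc(O)c(CCCNC(=O)c2ccc(-c3ccccn3)s2)c1`. For compound 2 this assay reports only a limit, > 2900 nM.
Compound 3, `N=C(N)c1ccc(O)c(/C=C/CNC(=O)c2ccc(-c3cccc(C(N)=O)c3)cc2)c1`. For compound 3 this assay reports only a limit, > 2900 nM.

Compound 3 therefore has no number of its own in this assay, only a limit, and it shares that limit with one other compound: the limit of > 2900 nM in this assay, at which 2 of the 3 values shown sit. Going by the values given here, no pair among the three measured compounds differs in a single place, so no measured step is available to guide the next change.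

Compound 4, `N=C(N)c1ccc(O)c(/C=C/CNC(=O)c2ccc(-c3ccc(S(N)(=O)=O)cc3)cc2)c1`, differs from compound 3 in one place: 4-sulfamoylphenyl in place of 3-carbamoylphenyl on an aromatic carbon. Among the compounds with values here, with no measured step of this kind, the change is expected to move the inhibition constant by no more than the usual scatter, so the expected step from compound 3 to compound 4 is a step that the limit leaves unreadable from compound 3 to compound 4. Compound 4 is therefore expected to give about 3500 nM in this assay, in a range from 1000 nM to 12000 nM, with a real chance that this assay again reports only a limit.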

Compound 4, inhibition constant: 1600 nM
Beside the measured number, compound 4's estimate is 2.2-fold (0.34 log units) above it; the range from low to high includes it.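

In this assay the change at this aromatic carbon gives an at least 1.8-fold lower number from compound 3 to compound 4 (0.25 log units; that floor lies within the scatter). This step rests on a limit for compound 3, so it is only a floor, but it shows that this position can carry 4-sulfamoylphenyl and still give a measured number, which compound 3 with 3-carbamoylphenyl does not. Compound 2 and compound 3 remain limits rather than numbers: the limit of > 2900 nM in this assay, at which 2 of the 4 values shown sit.

The step swaps the carbamoyl for the sulfamoyl and shifts the substituent on the phenyl ring at the same time, so the compounds shown cannot separate the effect of the group from that of its place on the ring. They also leave open how a carboxylic acid or an amine on that phenyl ring would read in this assay.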